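The compounds below may be only part of what the source reports. "The series", "measured", "known", "first", "only" and "open" are said of these compounds alone.

Three compounds share one core, and all three were tested in an assay on isolated protein for inhibition of Fatty-acid amide hydrolase 1 (Homo sapiens), read by fluorescence, with a stated time of 30 min; a higher number here means a weaker inhibitor, a lower number a stronger inhibitor. Compound 1 `CCOC(=O)c1cc(-c2ccc(OC(=O)NC3CCCCC3)cc2)nn1C`, with a methyl on the aromatic nitrogen, gives 316 nM. Compound 2 `CCOC(=O)c1cc(-c2ccc(OC(=O)NC3CCCCC3)cc2)nn1-c1ccccc1` carries a phenyl there and gives 592 nM, and compound 3 `CCOC(=O)c1cc(-c2ccc(OC(=O)NC3CCCCC3)cc2)nn1-c1ccc(Cl)cc1` carries a 4-chlorophenyl and gives 586 nM. On the numbers shown, compound 3 sits between the other two, yet both gaps are within the scatter: a 1.9-fold higher number from compound 1 to compound 3 (0.27 log units; within the scatter) and a 1.0-fold lower number from compound 2 to compound 3 (0.00 log units; within the scatter). The parallel step a 1.9-fold higher number from compound 1 to compound 2 (0.27 log units; within the scatter) is likewise within the scatter, so nothing in this assay has yet moved beyond the noise.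

Compound 4 `CCOC(=O)c1cc(-c2ccc(OC(=O)NC3CCCCC3)cc2)nn1-c1ccc(OC)cc1` is the next step from compound 3: methoxy in place of chloro on an aromatic carbon. Going by the values given here, the one measured step that touches the same position, a 1.0-fold lower number from compound 2 to compound 3 (0.00 log units; within the scatter), was flat, and the exchange of methyl for either aryl group in the steps from compound 1 changed the number by less than the scatter. On that basis the expected step in this assay, a 1.1-fold lower number from compound 3 to compound 4 (0.03 log units; within the scatter), is none beyond the scatter, in no clear direction. The estimate for compound 4 in this assay is therefore 550 nM, with a range from 250 nM to 1200 nM.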

Compound 4, half-maximal inhibitory concentration: 159 nM
Compound 4: the middle estimate sits 3.5-fold (0.54 log units) above what was measured; measured number below the stated range.
By their numbers in this assay, from the lowest: compounds 4, 1, 3 and 2 (each within the scatter of the next, the first and the last beyond it).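

In this assay, the substituent on the aromatic carbon para to a large group now shows a change beyond the scatter, with methoxy in place of chloro (a 3.7-fold lower number from compound 3 to compound 4 (0.57 log units; beyond the scatter)) and methoxy in place of hydrogen (a 3.7-fold lower number from compound 2 to compound 4 (0.57 log units; beyond the scatter)), whereas chloro in place of hydrogen had left the number flat (a 1.0-fold lower number from compound 2 to compound 3 (0.00 log units; within the scatter)). This position therefore responds to the group placed on it, and among hydrogen, chloro and methoxy only methoxy separates from the others. The shift holds only among the aryl compounds, since 4-methoxyphenyl in place of methyl on the aromatic nitrogen stays within the scatter (a 2.0-fold lower number from compound 1 to compound 4 (0.30 log units; within the scatter)).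

Nothing at hand explains why methoxy and chloro differ here. On these data alone, it remains open whether the oxygen itself matters or any small group attached through an atom of that kind would do the same, which an ethoxy, a hydroxyl, a dimethylamino or a plain methyl at this place could test, and whether the step survives a change elsewhere on the shared core.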